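Acetyl to Benzoyl on Two Enone Cores

A few compounds are considered here, and "the series" means these few. Any claim that something is new, unique, unknown or untested is made for them only; others in the source may bear on it.

Measured in a functional assay on HeLa cells (Homo sapiens) for inhibition, read by sulforhodamine B assay, with a stated time of 48 h (a higher number here means a weaker inhibitor of growth, a lower number a stronger inhibitor of growth), so far:
Compound 1, `CC(=O)OC/C(=C\C1CCCCC1)C(=O)c1ccccc1`: 21000 nM
Compound 2, `O=C(OC/C(=C\C1CCCCC1)C(=O)c1ccccc1)c1ccccc1`: 24000 nM
Compound 3, `CC(=O)OC/C(=C/c1ccc(Cl)cc1Cl)C(=O)c1ccccc1`: 22000 nM

Compound 2 arises from compound 1 by one change, (phenyl in place of methyl on a carbonyl carbon), and in this assay this gave a 1.1-fold higher number from compound 1 to compound 2 (0.06 log units; within the scatter). Compound 4, `O=C(OC/C(=C/c1ccc(Cl)cc1Cl)C(=O)c1ccccc1)c1ccccc1`, arises from compound 3 by phenyl in place of methyl on a carbonyl carbon. The two place lines read the same word for word, so this is the same change made on a second core; how the core of compound 3 differs from that of compound 1 is not broken down here. The three measured numbers all lie within the scatter of one another. Since the change left compound 1 essentially unmoved, it is expected to leave compound 3 unmoved too, so the estimated step is a 1.1-fold higher number from compound 3 to compound 4 (0.04 log units; within the scatter). Compound 4 is therefore estimated at 24000 nM in this assay, with a range from 12000 nM to 48000 nM.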

Compound 4, concentration for 50% growth inhibition: 8300 nM
Estimate against measurement, compound 4: 2.9-fold (0.46 log units) above; the whole stated range lies above it.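

In this assay, phenyl in place of methyl on a carbonyl carbon gave a 2.7-fold lower number from compound 3 to compound 4 (0.42 log units; beyond the scatter), a modest step. Set beside the earlier step, the same change does not carry over unaltered from one core to the other: the same change on two cores in this assay, a 1.1-fold higher number (0.06 log units; within the scatter) from compound 1 to compound 2 and a 2.7-fold lower number (0.42 log units; beyond the scatter) from compound 3 to compound 4, 3.0-fold (0.48 log units) apart, beyond the scatter of two such steps. Among the compounds shown here, this shows that the size of the step differed between these two cores, but with only two cores it does not show which difference between them matters, or what the change would do on a further core.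

The compounds shown leave open whether a longer chain in place of the phenyl would follow the core of compound 1 or the core of compound 3. They also leave open how an amine or a carboxylic acid on the benzoyl group would behave on either core.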